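The source may report more compounds than this note shows. Statements on the series, on what has been measured and on what is new or still open speak of the compounds shown alone.

Series notes. Compound 1 `COc1ccc(CNC(=O)[C@H](CC(=O)O)NC(=O)CNC(=O)c2cccc(NC(=N)N)c2)cc1` and compound 2 `N=C(N)Nc1cccc(C(=O)NCC(=O)N[C@@H](CC(=O)O)C(=O)NCc2cccc(-c3ccccc3)c2)c1` share one core and differ only on the saturated chain carbon bound to an amide-type nitrogen. In an assay on cells for displacement of a labelled ligand from protein Mdm4 (Homo sapiens), read by ELISA, with a stated time of 10 min (a lower number here means a stronger inhibitor, a higher number a weaker inhibitor), compound 1 gives > 1000 nM, a limit of the assay and not a number. In this assay compound 2 gives > 1000 nM, again a limit rather than a number. The step that the two limits leave unreadable from compound 1 to compound 2 therefore cannot be read, and compound 2 stands at the limit itself, with nothing in the series that places it more closely. Compound 3 `N=C(N)Nc1cccc(C(=O)NCC(=O)N[C@@H](CC(=O)O)C(=O)NCc2ccc(-c3ccccc3)cc2)c1` is the next change: 4-phenylphenyl in place of 3-phenylphenyl on a saturated chain carbon bound to an amide-type nitrogen. Going by the values given here, the one step measured so far touches the same position but has no readable size, and both values so far sit at the limit (the limit of > 1000 nM in this assay, at which 2 of the 2 values shown sit). No shift beyond the scatter is expected from compound 2 to compound 3, written as a step that the limit leaves unreadable from compound 2 to compound 3. Compound 3 is expected at 3000 nM, within 1000 nM to 20000 nM, most likely returned once more as a limit.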

Compound 3, half-maximal inhibitory concentration: > 1000 nM
Compound 3 ended at the assay's limit; the forecaster's own chance of this, stated with the estimate: 85%; the middle value lies beyond the limit too.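

In this assay, no new step can be read among compound 1, compound 2 and compound 3, since all three values are limits and not numbers: the limit of > 1000 nM in this assay, at which 3 of the 3 values shown sit. The compounds shown leave open how far each compound lies from that limit, and whether 3-phenylphenyl and 4-phenylphenyl differ at all.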